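The source may hold more compounds than are shown below. What is called first, only, known or untested is meant among the compounds shown, and "the series" means these compounds.

Compound 1 `Cc1c(Cc2ccc(-n3cccn3)cc2)cc(C(=O)N[C@H]2CCCC[C@@H]2O)c(=O)n1C`: 20 mL/min/kg
Compound 2 `Cc1c(Cc2ccc(-n3cccn3)cc2)cc(C(=O)N[C@H]2CCOC[C@@H]2O)c(=O)n1C`: < 8 mL/min/kg
Compound 3 `Cc1cnc(C(=O)N[C@H]2CCOC[C@@H]2O)cc1Cc1ccc(-n2cccn2)cc1`: < 8 mL/min/kg

In an ADME assay on microsomes from liver (Homo sapiens) for metabolic stability (a higher number here means faster removal of the compound, a lower number slower removal), compound 1 gives 20 mL/min/kg. For compound 2 the assay reports only a limit, < 8 mL/min/kg. For compound 3 it also reports only a limit, < 8 mL/min/kg. Compound 2 and compound 1 share one core and differ in a single place: 2-hydroxycyclohexyl in place of 3-hydroxyoxan-4-yl on an amide-type nitrogen. This change produced an at least 2.5-fold higher number from compound 2 to compound 1 (0.39 log units; beyond the scatter); because two of the three values sit at the limit of < 8 mL/min/kg in this assay, at which 2 of the 3 values shown sit, the step can only be given as a lower bound. Compound 3 carries a different core, and the difference between the two cores is not broken down here. Compound 4 `Cc1cnc(C(=O)N[C@H]2CCCC[C@@H]2O)cc1Cc1ccc(-n2cccn2)cc1` has not yet been measured. It stands to compound 3 exactly as compound 1 stands to compound 2: 2-hydroxycyclohexyl in place of 3-hydroxyoxan-4-yl on an amide-type nitrogen. The place of the change is the same in both pairs, so this is the same change. The step from compound 3 to compound 4 is expected to be an at least 2.2-fold higher number from compound 3 to compound 4 (0.35 log units; beyond the scatter), which rests on the earlier step of the same change, an at least 2.5-fold higher number from compound 2 to compound 1 (0.39 log units; beyond the scatter). Compound 4 is therefore expected to give about 18 mL/min/kg in this assay, most likely between 8 mL/min/kg and 40 mL/min/kg.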

Compound 4, clearance: 20 mL/min/kg
For compound 4 the middle estimate is 1.1-fold (0.05 log units) below the measured one; the measured number falls inside the stated range.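

In this assay, putting 2-hydroxycyclohexyl in place of 3-hydroxyoxan-4-yl on the amide-type nitrogen gives an at least 2.5-fold higher number from compound 3 to compound 4 (0.39 log units; beyond the scatter), and setting this beside the earlier step gives the following picture: the same change on two cores in this assay, an at least 2.5-fold higher number (0.39 log units; beyond the scatter) from compound 2 to compound 1 and an at least 2.5-fold higher number (0.39 log units; beyond the scatter) from compound 3 to compound 4; the limit leaves it open whether they differ

The change therefore carries over from one core to the other in direction, with the number going up on both cores and each step lying beyond the scatter. It does not show the true size of either step, or whether the two cores respond equally, since each step starts from a compound that sits at a limit: the limit of < 8 mL/min/kg in this assay, at which 2 of the 4 values shown sit.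

The compounds shown leave open how the number would move with other groups on that nitrogen, such as a cyclohexyl ring without the hydroxyl or a ring carrying an amine or a carboxylic acid. They also leave open whether the same change would act in the same direction on any core beyond these two.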